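The source may report more compounds than this note shows. Statements on the series, on what has been measured and on what is new or still open speak of the compounds shown alone.

Compound 1, `N#Cc1c(-c2ccccc2[N+](=O)[O-])c(C#N)c(=O)n(/N=C/c2cn(-c3ccccc3)nc2-c2ccccc2)c1N`, in an ADME assay on HeLa cells (Homo sapiens) for cytotoxicity, read by MTT assay (on this read-out higher numbers stand for weaker inhibition and lower numbers for stronger inhibition), gives > 200 ug/mL, which is a limit of the assay rather than a number.
Compound 2, `N#Cc1c(-c2cccc([N+](=O)[O-])c2)c(C#N)c(=O)n(/N=C/c2cn(-c3ccccc3)nc2-c2ccccc2)c1N`, in this assay gives > 200 ug/mL, again a limit of the assay and not a number.

Compound 2 therefore stands at the limit, where both values shown sit (the limit of > 200 ug/mL in this assay, at which 2 of the 2 values shown sit). Within the data shown here, the one measured step, a step that the two limits leave unreadable from compound 1 to compound 2, cannot be read, since both ends are limits. Compound 3, `N#Cc1c(-c2ccc(Br)cc2)c(C#N)c(=O)n(/N=C/c2cn(-c3ccccc3)nc2-c2ccccc2)c1N`, differs from compound 2 by 4-bromophenyl in place of 3-nitrophenyl on an aromatic carbon. Among the measured compounds shown here, no measured step bears on this change with a readable size, and compound 2 itself gives only a limit, so there is no footing for expecting any step beyond the scatter in either direction. The expectation for compound 3 is accordingly that this assay will again report a limit, with the estimate 250 ug/mL and a range from 100 ug/mL to 600 ug/mL, meaning an expected step that the limit leaves unreadable from compound 2 to compound 3.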

Compound 3, half-maximal inhibitory concentration: > 200 ug/mL
Compound 3: only a limit was reported (the forecaster's own chance of this, stated with the estimate: 80%); the middle value does not contradict the limit.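

Compound 3 also gives only a limit of the assay, so no step among compound 1, compound 2 and compound 3 can be read: the limit of > 200 ug/mL in this assay, at which 3 of the 3 values shown sit.

The compounds shown leave open whether the 2-nitrophenyl, 3-nitrophenyl and 4-bromophenyl groups differ at all in this assay, and which change to the shared core would give a readable number.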